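The source may report more compounds than this note shows. Statements on the series, on what has been measured and on what is new or still open speak of the compounds shown alone.

Two compounds share one core and differ only in the group on the distant aromatic ring. Compound 1 `CCCS(=O)(=O)Nc1ccc(F)c(C(=O)c2n[nH]c3ncc(-c4ccc(N(C)C)cc4)cc23)c1F` carries a dimethylamino group there; in an assay for binding affinity to dual specificity mitogen-activated protein kinase kinase 4 (Homo sapiens), read by KINOMEscan, tested at 100 nM (on this read-out higher numbers stand for a weaker effect at the one concentration tested and lower numbers for a stronger effect), compound 1 gives 2.5%. Compound 2 `CCCS(=O)(=O)Nc1ccc(F)c(C(=O)c2n[nH]c3ncc(-c4ccc(S(=O)(=O)NC)cc4)cc23)c1F` carries a methylsulfamoyl group instead, and in this assay compound 2 gives 1.2%. Compound 2 has the lowest of the two numbers shown, but the only step measured, a number 1.3 percentage points lower from compound 1 to compound 2 (within the scatter), lies within the scatter, so the two compounds cannot be ordered against each other.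

Compound 3 `CCCS(=O)(=O)Nc1ccc(F)c(C(=O)c2n[nH]c3ncc(-c4ccc(NS(C)(=O)=O)cc4)cc23)c1F` is not yet measured. It differs from compound 2 in this way: methanesulfonamido in place of methylsulfamoyl on an aromatic carbon. Going by the values given here, the one measured step shows that exchanging the group on that ring left the read-out essentially unchanged, and for the step to compound 3 no change beyond the scatter is therefore expected either, with a number 1.8 percentage points higher from compound 2 to compound 3 (within the scatter) as the estimated step. Compound 3 is expected to give about 3% in this assay, between 0.5% and 15%.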

Compound 3, a percentage reported as activity, at one concentration (the size of the read-out at that concentration, not a potency): 0.85%
Estimate against measurement, compound 3: 2.2 percentage points above; measured number inside the range.
By their numbers in this assay, from the lowest: compounds 3, 2 and 1 (each within the scatter of the next).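

Joining the same atoms differently, with methanesulfonamido in place of methylsulfamoyl, gives a number 0.4 percentage points lower from compound 2 to compound 3 (within the scatter) in this assay and so leaves the read-out unchanged within the usual scatter. Putting methanesulfonamido in place of dimethylamino gives a number 1.7 percentage points lower from compound 1 to compound 3 (within the scatter) in the same assay, which means that all three groups at this place, para to a large group, now read alike, and that turning the sulfur-containing group around makes no visible difference here. No measurement at hand offers a reason for this sameness.

Still open, on these data alone, is whether a carboxylic acid, a primary amine or a longer chain at this place would read the same. Also open, as far as these compounds go, is whether the three compounds, tested only at one concentration, would stay alike at a lower one.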